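The source may hold more compounds than are shown below. What is called first, only, known or untested is meant among the compounds shown, and "the series" means these compounds.

Measured compounds:
Compound 1 `CCc1oc2c(C)c(OCc3ccccc3)ccc2c(=O)c1Br` gives in a functional assay on DU-145 cells (Homo sapiens) for antiproliferative activity, read by sulforhodamine B assay, with a stated time of 72 h (on this read-out lower numbers stand for stronger inhibition of growth and higher numbers for weaker inhibition of growth), a result of > 26700 nM, which is a limit of the assay and not a number.
Compound 2 `CCc1cc(=O)c2ccc(OC)c(CBr)c2o1` gives in this assay > 33600 nM, again a limit of the assay.
Compound 3 `COc1ccc2c(=O)cc(C(C)Br)oc2c1CBr` gives in this assay > 26500 nM, also a limit of the assay.

Compound 3 thus stands at a limit, and none of the three values shown is a number: one sits at the limit of > 26500 nM in this assay, at which 1 of the 3 values shown sits, one at the limit of > 26700 nM in this assay, at which 1 of the 3 values shown sits, and one at the limit of > 33600 nM in this assay, at which 1 of the 3 values shown sits. For the measured compounds named here, the only pair that differs in one place is covered by a step that the two limits leave unreadable from compound 2 to compound 3, and that step cannot be read in either direction from two limits.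

Compound 4 `CC(C)Oc1ccc2c(=O)cc(C(C)Br)oc2c1CBr` differs from compound 3 by isopropyl in place of methyl on an oxygen on an aromatic ring. Going by the values given here, no measured step touches the group on the aromatic oxygen, so nothing among the measured compounds speaks to this change. What the data offer is three limits and one unreadable step, which leaves no ground for expecting a readable shift in this assay.

Compound 4 is therefore expected at 30000 nM, with a range from 8000 nM to 120000 nM. The expected step that the limit leaves unreadable from compound 3 to compound 4 is, by that estimate, no more than the scatter, and most likely the assay will again report a limit.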

Compound 4, concentration for 50% growth inhibition: 15500 nM
The estimate for compound 4 lay 1.9-fold (0.29 log units) above the measured number, and the stated range covers the measured number.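

For the compounds shown here, with isopropyl in place of methyl on an oxygen on an aromatic ring, the piece gains its only number in this assay: compound 4 gives 15500 nM. The change from methoxy to isopropoxy shows an at least 1.7-fold lower number from compound 3 to compound 4 (0.23 log units; that floor lies within the scatter), which makes this oxygen the only place among the compounds shown where a change can be followed to a readable step, although the floor of that step does not by itself clear the scatter. Compound 3 stands at a limit of the assay and not at a number, so the full size of the step stays unknown: the limit of > 26500 nM in this assay, at which 1 of the 4 values shown sits.

Going by these compounds, the step from compound 2 to compound 3 cannot be read, so the effect of bromo on the saturated chain carbon stays open, as does whether the change from methoxy to isopropoxy would read the same on the core of compound 2. Also open, on these data alone, is how a longer chain on that oxygen, such as hexyl, or a chain there ending in an amine or a carboxylic acid, would read in this assay.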